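A few compounds are considered here, and "the series" means these few. Any claim that something is new, unique, unknown or untested is made for them only; others in the source may bear on it.

Of the compounds shown here, three sharing one core have been tested in a functional assay on HUVEC cells (Homo sapiens) (a lower number here means that less compound is needed, a higher number that more compound is needed for the effect), and they differ only in the substituted phenyl group on the chain. Compound 1 `COC1=C(C)C(=O)/C(=C(O)/C=C/c2cccc(OC)c2)C(=O)C1(C)C` is reported only as a limit, < 4 ug/mL. Compound 2 `COC1=C(C)C(=O)/C(=C(O)/C=C/c2ccc(F)cc2)C(=O)C1(C)C` is likewise reported only as a limit, < 4 ug/mL. Compound 3 `COC1=C(C)C(=O)/C(=C(O)/C=C/c2ccccc2C)C(=O)C1(C)C` also stands at a limit, < 4 ug/mL, so it has no exact number. For the measured compounds named here, the series so far comes down to the limit of < 4 ug/mL in this assay, at which 3 of the 3 values shown sit.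

Compound 4 `COC1=C(C)C(=O)/C(=C(O)/C=C/c2c(C)cccc2C)C(=O)C1(C)C` follows from compound 3 through one change, (methyl in place of hydrogen on an aromatic carbon), which turns 2-methylphenyl into 2,6-dimethylphenyl. Going by the values given here, three measured steps bear on this, all exchanges of the phenyl group at that same place: a step that the two limits leave unreadable from compound 1 to compound 2, a step that the two limits leave unreadable from compound 1 to compound 3 and a step that the two limits leave unreadable from compound 2 to compound 3. None of them has a readable size, so they offer neither a magnitude nor a direction to carry over to the added methyl. No step beyond the scatter is therefore expected in this assay. The expectation rests on compound 3 and its limit of < 4 ug/mL. The expected step is a step that the limit leaves unreadable from compound 3 to compound 4, an estimate without a firm direction. Compound 4 is estimated at 2 ug/mL, with an expected range from 0.5 ug/mL to 6 ug/mL.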

Compound 4, concentration for half-maximal effect: < 4 ug/mL
Compound 4: no number, only a limit (the forecaster's own chance of this, stated with the estimate: 65%); the middle value is on the limit's open side.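

In this assay compound 4 is reported only as a limit, < 4 ug/mL. For the compounds shown here, no step from compound 1, compound 2 or compound 3 to compound 4 can be read, in either size or direction. The compounds shown leave open whether these phenyl groups differ at all in this assay, and by how much, as the series stays at a single limit: the limit of < 4 ug/mL in this assay, at which 4 of the 4 values shown sit.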